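Imide Nitrogen Substituents in a Sulfonamide Series

The compounds below may be only part of what the source reports. "The series", "measured", "known", "first", "only" and "open" are said of these compounds alone.

Compound 1 `Cc1ccc(S(=O)(=O)Nc2ccc3c(c2)C(=O)N(CCCCBr)C3=O)cc1`: in an assay on isolated protein for inhibition of lysosomal alpha-glucosidase (Rattus norvegicus), read by colorimetric assay (a higher number here means a weaker inhibitor, a lower number a stronger inhibitor), compound 1 gives > 200000 nM, which is a limit of the assay and not a number.
Compound 2 `Cc1ccc(S(=O)(=O)Nc2ccc3c(c2)C(=O)N(C)C3=O)cc1`: in this assay compound 2 gives > 200000 nM, again a limit of the assay.
Compound 3 `Cc1ccc(S(=O)(=O)Nc2ccc3c(c2)C(=O)N(Cc2ccccc2)C3=O)cc1`: in this assay compound 3 gives > 200000 nM, also a limit of the assay.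

Compound 3 therefore stands only at a limit, and the two other values known in this series are limits as well (the limit of > 200000 nM in this assay, at which 3 of the 3 values shown sit). None of the steps among the measured compounds can be read: a step that the two limits leave unreadable from compound 1 to compound 2, a step that the two limits leave unreadable from compound 1 to compound 3 and a step that the two limits leave unreadable from compound 2 to compound 3 are all left unreadable by the two limits that bound them.

Compound 4 `Cc1ccc(S(=O)(=O)Nc2ccc3c(c2)C(=O)N(CCOc2cccc(O)c2)C3=O)cc1` has not yet been measured. It differs from compound 3 by (3-hydroxyphenoxy)methyl in place of phenyl on a saturated chain carbon bound to an amide-type nitrogen in a ring. The change sits at the same place as the three measured steps, but since each of those is unreadable, none of them gives a size or a direction to carry over to compound 4.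

With nothing in the measured steps to point elsewhere, compound 4 is expected to sit at the limit too, so that a number no higher from compound 3 to compound 4 (the limit leaves the size open) is estimated to be no readable step. Compound 4 is thus estimated at 200000 nM, with a range from 50000 nM to 500000 nM.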

Compound 4, half-maximal inhibitory concentration: 55600 nM
Beside the measured number, compound 4's estimate is 3.6-fold (0.56 log units) above it; low and high end bracket the measured number.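

In this assay, among these compounds, the group on a saturated chain carbon bound to an amide-type nitrogen in a ring proves able to bring the number off the limit, which none of the earlier compounds showed: the series now holds an at least 3.5-fold lower number from compound 3 to compound 4 (0.55 log units; beyond the scatter), an at least 3.5-fold lower number from compound 2 to compound 4 (0.55 log units; beyond the scatter) and an at least 3.5-fold lower number from compound 1 to compound 4 (0.55 log units; beyond the scatter). Both the phenyl that leaves and the (3-hydroxyphenoxy)methyl that enters hold one six-membered aromatic ring of carbon only, so that ring alone does not separate compound 3 from compound 4, and the step goes with the larger group that also brings the oxygens and the hydroxyl. All three steps remain bounds and not sizes, because each starts from a compound whose value is a limit: the limit of > 200000 nM in this assay, at which 3 of the 4 values shown sit.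

The compounds shown do not separate the hydroxyl from the ether oxygen or from the longer chain, so it stays open which of these parts goes with the step. Also open, on these data alone, is how a plain 2-phenoxyethyl group, an amine or a carboxylic acid in place of the hydroxyl, or a longer chain between the nitrogen and the ether oxygen would read.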